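The source may hold more compounds than are shown below. What is called first, only, known or untested is meant among the compounds shown, and "the series" means these compounds.

Going by the values given here, compound 2 `COc1cc(Cl)cc(-c2nn(-c3cccc(NC(=O)Nc4ccc(Cl)c(Cl)c4)c3)cc2-c2ccncc2)c1` stands at the top of the two numbers so far in a functional assay on PC-3 cells (Homo sapiens) for inhibition, read by sulforhodamine B assay, with a stated time of 48 h; a higher number here means a weaker inhibitor, a lower number a stronger inhibitor. In this assay compound 2 gives 1130 nM. Among the compounds with values here, the only comparator is compound 1 `COc1cc(Cl)cc(-c2nn(-c3cccc(NC(=O)Nc4cc(C(F)(F)F)cc(C(F)(F)F)c4)c3)cc2-c2ccncc2)c1`, which in this assay gives 300 nM, a gap that lies beyond the usual scatter; compound 1 carries two trifluoromethyl groups on the ring attached to the urea where compound 2 carries two chlorines.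

Compound 3 `COc1cc(Cl)cc(-c2nn(-c3cccc(NC(=O)Nc4cccc(C(F)(F)F)c4)c3)cc2-c2ccncc2)c1` changes that ring once more: 3-(trifluoromethyl)phenyl in place of 3,4-dichlorophenyl on an amide-type nitrogen. Within the data shown here, no measured pair isolates this exact exchange, so the step can only be expected from the two numbers in hand. A move toward a lower number seems more likely than a move upward, because compound 1 with its trifluoromethyl-bearing ring gives 300 nM while compound 2 with the dichlorophenyl ring gives 1130 nM; a single trifluoromethyl group, however, need not carry the whole of that difference. Compound 3 is therefore expected near 600 nM, with a range from 250 nM to 1500 nM. This estimate means a step of a 1.9-fold lower number from compound 2 to compound 3 (0.27 log units; within the scatter), expected to be modest and close to the edge of the scatter.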

Compound 3, half-maximal inhibitory concentration: 420 nM
For compound 3 the middle estimate is 1.4-fold (0.15 log units) above the measured one, within the range that was stated.
By their numbers in this assay, from the lowest: compounds 1 and 3 (each within the scatter of the next); then compound 2.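

In this assay, going by these compounds alone, 3-(trifluoromethyl)phenyl in place of 3,4-dichlorophenyl on the amide-type nitrogen gives a 2.7-fold lower number from compound 2 to compound 3 (0.43 log units; beyond the scatter), the first single-place change at this position that can be read directly, and it lies beyond the usual scatter. Within the data shown here, the other single-place comparison, hydrogen in place of trifluoromethyl on an aromatic carbon, gives a 1.4-fold higher number from compound 1 to compound 3 (0.15 log units; within the scatter), so the second trifluoromethyl group makes no difference that can be told from the scatter in this small set, and the one trifluoromethyl group of compound 3 is enough for a value that cannot be separated from that of compound 1. The compounds shown offer no measurement that would explain either step.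

Going by these compounds, it remains open whether a ring with a single fluorine, methoxy or nitrile on it, or a plain phenyl, would stand with compound 3 or with compound 2. The compounds shown also leave open whether a saturated group such as cyclohexyl on the amide-type nitrogen would keep a value of this order, and whether these steps would hold with other groups on the shared core.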